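A Bromo Substituent Tested on Two Related Cores

The compounds below may be only part of what the source reports. "The series", "measured", "known", "first", "only" and "open" are said of these compounds alone.

The study looked at small methylene-bearing compounds carrying a phenyl ring, tested in a functional assay on NALM-6 cells (Homo sapiens) for cytotoxicity, read by MTT assay, with a stated time of 48 h; on this read-out higher numbers stand for weaker inhibition and lower numbers for stronger inhibition. Compound 1 `C=C1CC(c2ccccc2)OC1=O` gave 9130 nM. Compound 2 `C=C1CC(c2ccc(Br)cc2)OC1=O`, in which the change is bromo in place of hydrogen on an aromatic carbon, gave 85300 nM, a step of a 9.3-fold higher number from compound 1 to compound 2 (0.97 log units; beyond the scatter). Compound 3 `C=C1CC(c2ccccc2)N(C)C1=O` has a different core; the difference between the two cores is not broken down here. In this assay compound 3 gave 553000 nM, the highest number of the three.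

Compound 4 `C=C1CC(c2ccc(Br)cc2)N(C)C1=O` carries the change bromo in place of hydrogen on an aromatic carbon on the core of compound 3. This is the same kind of change as that from compound 1 to compound 2, though the bromo enters para to a group of 7 heavy atoms in the one case and para to a group of 8 heavy atoms in the other. Because the earlier change produced a 9.3-fold higher number from compound 1 to compound 2 (0.97 log units; beyond the scatter), a weakening step of similar size is expected here as well, a 4.5-fold higher number from compound 3 to compound 4 (0.66 log units; beyond the scatter). Compound 4 is therefore estimated at 2500000 nM in this assay, with a range from 700000 nM to 9000000 nM, and there is a real chance the assay reports only a limit.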

Compound 4, half-maximal inhibitory concentration: 141000 nM
Compound 4: middle estimate off by 18-fold (1.25 log units), on the high side; measured number outside the range, below it.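

On the core of compound 3, bromo in place of hydrogen on an aromatic carbon gave a 3.9-fold lower number from compound 3 to compound 4 (0.59 log units; beyond the scatter) in this assay. Set beside the step on the core of compound 1, the same change ran in the opposite direction, and so its effect did not carry from one core to the other in this series: the same change on two cores in this assay, a 9.3-fold higher number (0.97 log units; beyond the scatter) from compound 1 to compound 2 and a 3.9-fold lower number (0.59 log units; beyond the scatter) from compound 3 to compound 4, 37-fold (1.56 log units) apart, beyond the scatter of two such steps The comparison rests on a single pair on each core; it shows that the outcome of this change depends on the core, but not which difference between the two cores is responsible, nor what the change would do on a further core.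

The compounds shown leave open whether another group on the aromatic ring, such as chloro, methoxy or an amine, would also part the two cores in this way. They also leave open whether the opposite directions would hold for a carboxylic acid or a longer chain in that place.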